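A few compounds are considered here, and "the series" means these few. Any claim that something is new, unique, unknown or untested is made for them only; others in the source may bear on it.

In an ADME assay on microsomes from liver (Homo sapiens) for pharmacokinetics (on this read-out lower numbers stand for slow clearance and higher numbers for fast clearance), compound 3 `CC1CC1C(=O)N1CCN(c2nc(-c3cnn(C)c3)ncc2C#N)C[C@H]1C` gives < 16 mL/min/kg as its reading, which is a limit of the assay and not a number. Compound 1 `C[C@@H]1C[C@H]1C(=O)N1CCN(c2nc(-c3cnn(C)c3)ncc2C#N)C[C@H]1C` gives < 16 mL/min/kg as its reading, again a limit. Compound 2 `C[C@@H]1CN(c2nc(-c3cnn(C)c3)ncc2C#N)CCN1C(=O)C1CCC1` gives < 16 mL/min/kg as its reading, also a limit. Compound 3 therefore has no number of its own and shares one limit with the other two. Compound 4 `CCC(=O)N1CCN(c2nc(-c3cnn(C)c3)ncc2C#N)C[C@H]1C` differs from it by ethyl in place of 2-methylcyclopropyl on a carbonyl carbon in its structure, that is, ethyl in place of 2-methylcyclopropyl on a carbonyl carbon. The closest evidence is a step that the two limits leave unreadable from compound 2 to compound 3 at the same place, together with a step that the two limits leave unreadable from compound 1 to compound 2 there too, and neither can be sized because of the limit of < 16 mL/min/kg in this assay, at which 3 of the 3 values shown sit, in both cases. The change in a step that the two limits leave unreadable from compound 2 to compound 3 still left the reading at the limit, and the same is expected here. The expected result in this assay is a step that the limit leaves unreadable from compound 3 to compound 4 and nothing beyond the scatter. Compound 4 is estimated at 12 mL/min/kg with an expected range from 7 mL/min/kg to 20 mL/min/kg and will probably be reported only as a limit.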

Compound 4, clearance: < 16 mL/min/kg
Compound 4: only a limit was reported; the forecaster's own chance of this, stated with the estimate: 80%; the middle value does not contradict the limit.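

Going by these compounds alone, no step from compound 1, compound 2 or compound 3 to compound 4 can be read, because all the readings stop at the same limit: the limit of < 16 mL/min/kg in this assay, at which 4 of the 4 values shown sit. In this assay the compounds shown leave open how the true clearances of compounds 1, 2, 3 and 4 compare.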